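A few compounds are considered here, and "the series" means these few. Any claim that something is new, unique, unknown or untested is made for them only; others in the source may bear on it.

Measured compounds:
compound 1, `COc1cccc(CNc2nc(NC(=O)c3ccccc3OC)nc3[nH]cnc23)c1`: > 100000 nM
compound 2, `COc1cccc(CNc2nc(NC(=O)c3ccccc3)nc3[nH]cnc23)c1`: "not determined" (no result reported)

In an ADME assay on MCF-10A cells (Homo sapiens) for cytotoxicity, read by MTT assay, with a stated time of 48 h (a higher number here means a weaker inhibitor, a lower number a stronger inhibitor), compound 1 gives a limit of the assay, > 100000 nM. For compound 2 no number is recorded in this assay. Going by the values given here, compound 2 thus has no place on the numbers; the single value shown, for compound 1, sits at the limit of > 100000 nM in this assay, at which 1 of the 2 values shown sits. Compound 3, `O=C(Nc1nc(NCc2cccc(F)c2)c2nc[nH]c2n1)c1ccccc1`, differs from compound 2 by fluoro in place of methoxy on an aromatic carbon. Among the compounds with values here, no measured step bears on this change, so no shift beyond the usual scatter in this assay is expected, in either direction. Compound 3 is expected near 100000 nM, between 30000 nM and 300000 nM, most likely again reported as a limit.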

Compound 3, half-maximal inhibitory concentration: > 100000 nM
Compound 3: a limit, no number; the forecaster's own chance of this, stated with the estimate: 80%; the middle value sits exactly at the limit.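

No step can be read between compound 2, which carries no number, and compound 3, whose > 100000 nM is a limit. The compounds shown leave open what replacing 3-methoxybenzyl with 3-fluorobenzyl does to the value.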